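A few compounds are considered here, and "the series" means these few. Any claim that something is new, unique, unknown or untested is made for them only; others in the source may bear on it.

Measured so far in a functional assay on HCT-116 cells (Homo sapiens) for inhibition, read by CCK-8 assay, with a stated time of 48 h; a higher number here means a weaker inhibitor, a lower number a stronger inhibitor:
compound 1 `Cn1ccc2cc(-c3cc4nccc(-c5ccc(F)cc5)n4n3)ccc21` gives 2160 nM
compound 2 `COc1cc(-c2ccnc3cc(-c4ccccc4)nn23)cc(OC)c1OC` gives 3880 nM
compound 3 `COc1cc(-c2ccnc3cc(-c4cn(C(=O)OC(C)(C)C)c5ccccc45)nn23)cc(OC)c1OC` gives 5720 nM

On these three numbers compound 2 stands second highest. Its nearest neighbour is compound 3, whose number is higher, but that gap stays within the usual scatter of this assay; its furthest is compound 1, whose number is lower, and that gap too lies within the scatter. None of the three is told apart from the others; the set sits in one narrow band.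

Compound 4 `C=Cc1ccc(-c2cc3nccc(-c4cc(OC)c(OC)c(OC)c4)n3n2)cc1` has not been measured. It differs from compound 2 in one place: vinyl in place of hydrogen on an aromatic carbon. Cut one bond further out, the same difference reads phenyl to 4-vinylphenyl. Everything else is shared with compound 2.

Going by the values given here, no measured pair shows what a vinyl entering in this way does, and nothing among compounds 1, 2 and 3 speaks to it. Since the measured compounds all lie within the scatter of one another, no step beyond the scatter is expected in this assay from this change, in either direction. Compound 4 is expected to give 3200 nM, with a range of 1200 nM to 8500 nM. The step of a 1.2-fold lower number from compound 2 to compound 4 (0.08 log units; within the scatter) that this estimate means is expected to stay within the scatter.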

Compound 4, half-maximal inhibitory concentration: 1060 nM
Beside the measured number, compound 4's estimate is 3.0-fold (0.48 log units) above it, outside the stated range (below it).
By their numbers in this assay, from the lowest: compound 4; then compounds 1, 2 and 3 (each within the scatter of the next, the first and the last beyond it).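

In this assay, going by these compounds alone, vinyl in place of hydrogen, on an aromatic carbon para to a large group, gives a 3.7-fold lower number from compound 2 to compound 4 (0.56 log units; beyond the scatter) and is the first step between compounds that differ in one place. The earlier compounds shown here could not show whether this position matters; it does, since a modest change here moves the number beyond the scatter, towards a stronger inhibitor, so the position accepts a vinyl without loss and is worth further substitution. Nothing available explains this step, so it stands as an observation on a single pair of compounds.

Still open, on these data alone, is whether the step belongs to vinyl itself or would follow from any group at this carbon; an ethyl, a methoxy, an amine or a carboxylic acid in the same place would help separate those readings. Also open, as far as these compounds go, is whether the same change gives a similar step when other parts of the molecule differ, as a single pair cannot show how far it carries across the series.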